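Chloro-to-fluoro exchange on the methylsulfonylpiperidine urea

The source may report more compounds than this note shows. Statements on the series, on what has been measured and on what is new or still open speak of the compounds shown alone.

Measured so far:
- compound 1 `CC(C)N(CCN(C(=O)Nc1ccc(F)c(Cl)c1)C1CC[C@]2(c3cccc(C#N)c3)CC2C1)C(C)C` gives 4.98 nM in a functional assay for antagonist activity at melanin-concentrating hormone receptor 1 (Homo sapiens); on this read-out higher numbers stand for weaker inhibition and lower numbers for stronger inhibition
- compound 2 `CC(C)N(CCN(C(=O)Nc1ccc(F)c(F)c1)C1CC[C@]2(c3cccc(C#N)c3)CC2C1)C(C)C` gives 2.8 nM in this assay
- compound 3 `CS(=O)(=O)N1CCC(CN(C(=O)Nc2ccc(F)c(Cl)c2)C2CC[C@]3(c4cccc(C#N)c4)CC3C2)CC1` gives 7.19 nM in this assay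

Compound 3 differs from compound 1 in the core: 1-(methylsulfonyl)piperidin-4-yl in place of (diisopropylamino)methyl on a saturated chain carbon bound to an amide-type nitrogen; the step in this assay is a 1.4-fold higher number from compound 1 to compound 3 (0.16 log units; within the scatter).

Compound 4 `CS(=O)(=O)N1CCC(CN(C(=O)Nc2ccc(F)c(F)c2)C2CC[C@]3(c4cccc(C#N)c4)CC3C2)CC1` is not yet measured. It differs from compound 3 by fluoro in place of chloro on an aromatic carbon. The same change has been made once before, from compound 1 to compound 2: fluoro in place of chloro on an aromatic carbon, where a 1.8-fold lower number from compound 1 to compound 2 (0.25 log units; within the scatter). The two place descriptions match word for word, so this is the same change on a different core.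

Within the data shown here, for compound 4 in this assay a step of about a 1.8-fold lower number from compound 3 to compound 4 (0.25 log units; within the scatter) is expected, resting on the one earlier instance of this change, a 1.8-fold lower number from compound 1 to compound 2 (0.25 log units; within the scatter). Compound 4 is thus estimated at 4 nM, with a range from 2 nM to 8 nM.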

Compound 4, inhibition constant: 5.4 nM
Compound 4: the middle estimate sits 1.4-fold (0.13 log units) below what was measured; the measured number falls inside the stated range.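

In this assay the exchange of chloro for fluoro on the methylsulfonylpiperidine core gives a 1.3-fold lower number from compound 3 to compound 4 (0.12 log units; within the scatter), and the two cores agree on this change: the same change on two cores in this assay, a 1.8-fold lower number (0.25 log units; within the scatter) from compound 1 to compound 2 and a 1.3-fold lower number (0.12 log units; within the scatter) from compound 3 to compound 4, 1.3-fold (0.13 log units) apart, within the scatter of two such steps

The exchange of the side chain, read on the 3,4-difluorophenyl pair, gives a 1.9-fold higher number from compound 2 to compound 4 (0.29 log units; within the scatter), and it agrees with the same exchange on the 3-chloro-4-fluorophenyl pair: the same change on two cores in this assay, a 1.4-fold higher number (0.16 log units; within the scatter) from compound 1 to compound 3 and a 1.9-fold higher number (0.29 log units; within the scatter) from compound 2 to compound 4, 1.3-fold (0.13 log units) apart, within the scatter of two such steps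

Every one of these steps lies within the scatter and each change rests on two pairs only, so the four compounds show that the changes carry across without a step beyond the scatter, not that either has a reliable direction or would behave alike on other cores.

Open, on these data alone, is how hydrogen, methyl or methoxy would read in place of the chloro. Also open, as far as these compounds go, is how a primary amine or a carboxylic acid would read in place of the diisopropylamino or methylsulfonylpiperidine groups.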